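A Methyl Step Repeated on a Second Core

The source may report more compounds than this note shows. Statements on the series, on what has been measured and on what is new or still open speak of the compounds shown alone.

Compound 1, `Cc1ccccc1OS(=O)(=O)c1cccc(NC(=O)NCCCCl)c1`, gives 29000 nM in a functional assay on M21 cells (Homo sapiens) for cytotoxicity, read by sulforhodamine B assay, with a stated time of 48 h; a higher number here means a weaker inhibitor, a lower number a stronger inhibitor.
Compound 2, `CCc1ccccc1OS(=O)(=O)c1cccc(NC(=O)NCCCCl)c1`, gives 24000 nM in this assay.
Compound 3, `Cc1ccccc1OS(=O)(=O)c1ccc(NC(=O)NCCCCl)cc1`, gives 25000 nM in this assay.

The change from compound 1 to compound 2 is methyl in place of hydrogen on a saturated chain carbon bound to an aromatic carbon, and it produced a 1.2-fold lower number from compound 1 to compound 2 (0.08 log units; within the scatter). The unmeasured compound 4, `CCc1ccccc1OS(=O)(=O)c1ccc(NC(=O)NCCCCl)cc1`, differs from compound 3 by methyl in place of hydrogen on a saturated chain carbon bound to an aromatic carbon, the same change at the same place. Compound 1 and compound 3 share their atoms joined differently; the difference between their cores is not broken down here. Compound 3 and compound 2 lie within the scatter of each other. Because a 1.2-fold lower number from compound 1 to compound 2 (0.08 log units; within the scatter) stayed within the scatter, the step for compound 4 is expected to be a 1.2-fold lower number from compound 3 to compound 4 (0.08 log units; within the scatter). Compound 4 is therefore estimated at 21000 nM, between 12000 nM and 38000 nM.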

Compound 4, half-maximal inhibitory concentration: 15000 nM
Compound 4: the middle estimate sits 1.4-fold (0.15 log units) above what was measured; measured number inside the range.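

On the second core, methyl in place of hydrogen on a saturated chain carbon bound to an aromatic carbon gave a 1.7-fold lower number from compound 3 to compound 4 (0.22 log units; within the scatter) in this assay. Set beside the earlier step, the change carried from one core to the other with no gap beyond the scatter: the same change on two cores in this assay, a 1.2-fold lower number (0.08 log units; within the scatter) from compound 1 to compound 2 and a 1.7-fold lower number (0.22 log units; within the scatter) from compound 3 to compound 4, 1.4-fold (0.14 log units) apart, within the scatter of two such steps. Both steps lie within the scatter, however, so the pair does not show that the change has a real effect on either core, nor whether a larger effect would carry over in the same way.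

The compounds shown leave open whether a longer chain, such as propyl, would move the number beyond the scatter on either core. As far as these compounds go, how an amine or a carboxylic acid at that place would compare also remains open.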